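Sulfanyl to Allylsulfanyl on the Shared Core

A few compounds are considered here, and "the series" means these few. Any claim that something is new, unique, unknown or untested is made for them only; others in the source may bear on it.

Compound 1, `Cc1nnc(S)n2c(C)nc(C)c12`, in a functional assay for inhibition, with Homo sapiens as the target; a higher number here means a weaker inhibitor, a lower number a stronger inhibitor: > 48000 nM, a limit.
Compound 2, `Cc1ncc2cnnc(S)n12`, in this assay: > 48000 nM, a limit.
Compound 3, `Cc1nc(C)n2c(S)nncc12`, in this assay: > 48000 nM, a limit.

Compound 3 stands only at a limit in this assay, not at a number. Compound 4, `C=CCSc1nncc2c(C)nc(C)n12`, differs from compound 3 by allyl in place of hydrogen on a sulfur. The two measured steps leading to compound 3, a step that the two limits leave unreadable from compound 1 to compound 3 and a step that the two limits leave unreadable from compound 2 to compound 3, cannot be read, because of the limit of > 48000 nM in this assay, at which 3 of the 3 values shown sit. Among the measured compounds shown here, no measured step here touches the sulfur, so nothing shows how an allyl there moves the read-out in this assay. The step of an at least 1.0-fold lower number from compound 3 to compound 4 (0.02 log units; that floor lies within the scatter) is therefore expected to be none beyond the scatter, with wide uncertainty. Compound 4 is estimated at 45000 nM, between 8000 nM and 150000 nM, and most probably again a limit.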

Compound 4, half-maximal inhibitory concentration: 59000 nM
Beside the measured number, compound 4's estimate is 1.3-fold (0.12 log units) below it; low and high end bracket the measured number.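

No step can be read between compound 3 and compound 4, because compound 3 stands only at a limit in this assay: the limit of > 48000 nM in this assay, at which 3 of the 4 values shown sit. The compounds shown leave open how far allylsulfanyl in place of sulfanyl moves the read-out on the shared core.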